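This account rests on a few compounds, and the source may have more. Where it says the series, first, only, none or still open, it means among the compounds named here.

Measured so far in a functional assay on SK-OV-3 cells (Homo sapiens) for cytotoxicity, read by MTT assay, with a stated time of 3 days; on this read-out higher numbers stand for weaker inhibition and lower numbers for stronger inhibition:
Compound 1 `N#Cc1c(NC(N)=O)nc(SCc2nc3ccccc3[nH]2)nc1-c1ccccc1`: 6.75 nM
Compound 2 `CN1CCN(c2nc(SCc3nc4ccccc4[nH]3)nc(-c3ccccc3)c2C#N)CC1`: 1600 nM
Compound 3 `N#Cc1c(-c2ccccc2)nc(SCc2nc3ccccc3[nH]2)nc1N1CCN(S(=O)(=O)c2ccccc2)CC1`: 2.77 nM

Compound 3, at 2.77 nM, has the lowest number of the three. Compound 1 follows at 6.75 nM, and compound 2 lies far higher at 1600 nM.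

Compound 4 `N#Cc1c(-c2ccccc2)nc(SCc2nc3ccccc3[nH]2)nc1N1CCN(S(=O)(=O)c2ccccc2[N+](=O)[O-])CC1` is compound 3 with nitro in place of hydrogen on an aromatic carbon, so phenylsulfonyl becomes (2-nitrophenyl)sulfonyl: nitro in place of hydrogen on an aromatic carbon. Within the data shown here, no measured step alters this ring, so the evidence is indirect. The closest is a 580-fold lower number from compound 2 to compound 3 (2.76 log units; beyond the scatter), where phenylsulfonyl took the place of methyl on an amine nitrogen in a ring. The other is a 240-fold higher number from compound 1 to compound 2 (2.37 log units; beyond the scatter), where 4-methylpiperazin-1-yl took the place of ureido. Both were large, but each exchanged a whole group, whereas compound 4 retains the phenylsulfonyl of compound 3. A far smaller step is therefore expected in this assay, probably towards a slightly higher number and possibly none beyond the scatter.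

For compound 4 the estimated value is 4 nM, with an expected range from 1 nM to 20 nM.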

Compound 4, half-maximal inhibitory concentration: 3.2 nM
The estimate for compound 4 lay 1.3-fold (0.10 log units) above the measured number, within the range that was stated.
By their numbers in this assay, from the lowest: compounds 3 and 4 (each within the scatter of the next); then compound 1; then compound 2.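

In this assay, among these compounds, nitro in place of hydrogen on an aromatic carbon gives a 1.2-fold higher number from compound 3 to compound 4 (0.06 log units; within the scatter), the first reading of a change on this six-membered aromatic ring of carbon only, and a nitro group ortho to a large group leaves the number within the scatter. The large gain over the methyl compound also holds with the substituted ring, with (2-nitrophenyl)sulfonyl in place of methyl giving a 500-fold lower number from compound 2 to compound 4 (2.70 log units; beyond the scatter). Nothing measured on these compounds offers an explanation for this result.

The compounds shown carry only hydrogen or nitro on this ring, so they cannot tell whether an amine, a methoxy group or a chlorine atom at the same place would also leave the number within the scatter. As far as these compounds go, whether nitro would do the same elsewhere on the ring also remains open.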